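Clearance of compound 3 after a pyridine-bearing side-chain change

The source may hold more compounds than are shown below. What is called first, only, known or untested is meant among the compounds shown, and "the series" means these compounds.

- compound 1 `O=C(NCc1cc(Cl)ccc1-n1cnnn1)[C@@H]1C[C@@H]2C[C@@H]2N1C(=O)[C@H](O)c1cccc(Cl)c1`: > 500 mL.min-1.g-1 (a limit)
- compound 2 `O=C(NCc1cc(Cl)ccc1-n1cnnn1)[C@@H]1C[C@@H]2C[C@@H]2N1C(=O)[C@H](O)c1ccccc1`: < 16 mL.min-1.g-1 (a limit)
- compound 3 `O=C(NCc1cc(Cl)ccc1-n1cnnn1)[C@@H]1C[C@@H]2C[C@@H]2N1C(=O)[C@H](O)Cc1ccccn1`: not yet measured

In an ADME assay on liver for metabolic stability, with Liver microsome (Homo sapiens) as the target, read by LC-MS, using microsomes (on this read-out higher numbers stand for fast clearance and lower numbers for slow clearance), compound 2 gives < 16 mL.min-1.g-1, which is a limit and not a number. Among the measured compounds shown here, the only other value, that of compound 1, is also a limit.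

The structural change to compound 3 is (pyridin-2-yl)methyl in place of phenyl on a saturated chain carbon bound to a carbonyl carbon and an oxygen on a saturated carbon. For the measured compounds named here, the one measured step, an at least 31-fold lower number from compound 1 to compound 2 (1.49 log units; beyond the scatter), is hydrogen in place of chloro on an aromatic carbon. Going by the values given here, it is large, but it lies at a different place, so it shows only that one change can move the read-out far and gives no direct size for this change. A modest move toward faster clearance is expected, with the estimated step being an at least 1.2-fold higher number from compound 2 to compound 3 (0.09 log units; that floor lies within the scatter). The estimated value for compound 3 is 20 mL.min-1.g-1, with an expected range from 8 mL.min-1.g-1 to 70 mL.min-1.g-1.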

Compound 3, intrinsic clearance in microsomes: 17 mL.min-1.g-1
For compound 3 the middle estimate is 1.2-fold (0.07 log units) above the measured one; low and high end bracket the measured number.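

In this assay, the exchange of phenyl for (pyridin-2-yl)methyl at this position gives an at least 1.0-fold higher number from compound 2 to compound 3 (0.02 log units; that floor lies within the scatter), so the larger group can be carried here with no step beyond the scatter shown. Its size cannot be fixed, because compound 2 stands at a limit and not a number: the limit of < 16 mL.min-1.g-1 in this assay, at which 1 of the 3 values shown sits.

Set against the chlorinated group, the same new group gives an at least 29-fold lower number from compound 1 to compound 3 (1.46 log units; beyond the scatter), which shows that slow clearance at this position is not confined to phenyl; this step is only a floor, because compound 1 also stands at a limit: the limit of > 500 mL.min-1.g-1 in this assay, at which 1 of the 3 values shown sits.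

The compounds shown leave open how a plain benzyl group would read at this position, which would separate the ring nitrogen from the change in chain. They also leave open whether a chloro on the pyridine ring would return the read-out toward that of compound 1.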